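The source may hold more compounds than are shown below. What is called first, only, known or untested is meant among the compounds shown, and "the series" means these compounds.

Working notes on the series, all read in a functional assay on HCT-15 cells (Homo sapiens) for cytotoxicity, read by CCK-8 assay, with a stated time of 4 days; on this read-out higher numbers stand for weaker inhibition and lower numbers for stronger inhibition. Compound 2 (`Oc1ccc(-c2cc(-c3cccc(O)c3)cc(-c3cccc(O)c3)n2)cc1`) gives 3090 nM and compound 3 (`Oc1cccc(-c2cc(-c3cccc(O)c3)nc(-c3cccc(O)c3)c2)c1`) gives 3950 nM. Among the compounds with values here, these are the only two true numbers so far, and a 1.3-fold higher number from compound 2 to compound 3 (0.11 log units; within the scatter) lies within the scatter. Compound 1 (`Oc1cccc(-c2cc(-c3cccc(O)c3)nc(-c3ccccc3O)c2)c1`) gives > 50000 nM, which is a limit of the assay.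

Compound 4 (`Oc1ccc(-c2cc(-c3cccc(O)c3)cc(-c3ccccc3O)n2)cc1`) differs from compound 2 by 2-hydroxyphenyl in place of 3-hydroxyphenyl on an aromatic carbon: 2-hydroxyphenyl in place of 3-hydroxyphenyl, next to the ring nitrogen. Within the data shown here, the nearest precedent is the same exchange read in reverse, an at least 12-fold lower number from compound 1 to compound 3 (1.10 log units; beyond the scatter), which is large and beyond the scatter. The step of an at least 16-fold lower number from compound 1 to compound 2 (1.20 log units; beyond the scatter) is also large and places the 2-hydroxyphenyl group against compound 2 directly. Among the measured compounds shown here, both steps end on a limit, so each gives only a minimum size, and only this one pair of steps bears on the exchange.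

A large step toward a higher number is therefore expected, with weaker inhibition. The expected step is a 6.5-fold higher number from compound 2 to compound 4 (0.81 log units; beyond the scatter). Compound 4 is estimated at 20000 nM, with an expected range of 6000 nM to 50000 nM.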

Compound 4, half-maximal inhibitory concentration: > 50000 nM
Compound 4 was reported as a limit (the forecaster's own chance of this, stated with the estimate: 35%); at least 2.5-fold (0.39 log units) between middle value and limit.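

In this assay, 2-hydroxyphenyl in place of 3-hydroxyphenyl next to the ring nitrogen also gives much weaker inhibition when the other two aryl groups differ, an at least 16-fold higher number from compound 2 to compound 4 (1.20 log units; beyond the scatter). The loss is therefore no longer tied to the core of compound 1, and it appears with a 4-hydroxyphenyl group as well as with a 3-hydroxyphenyl group at the neighbouring site: the same change on two cores in this assay, an at least 12-fold lower number (1.10 log units; beyond the scatter) from compound 1 to compound 3 and an at least 16-fold lower number (1.20 log units; beyond the scatter) from compound 4 to compound 2; the limit leaves it open whether they differ Compound 1 and compound 4 both stand at a limit, and the step between them cannot be read: the limit of > 50000 nM in this assay, at which 2 of the 4 values shown sit.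

The compounds shown give no true number for any compound carrying 2-hydroxyphenyl, so the full size of the loss stays open. Also open, on these data alone, is whether 2-methoxyphenyl or 2-aminophenyl in the same place would behave like 2-hydroxyphenyl.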